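Cyano removal on the biaryl tail, two cores

The source may report more compounds than this note shows. Statements on the series, on what has been measured and on what is new or still open speak of the compounds shown alone.

Compound 1 `Cc1ccc(CN2CCC(NC(=O)NCc3ccc(-c4cccc(C#N)c4)cc3)CC2)cc1` gives 411 nM in an in vitro functional assay on HEK293 cells for antagonist activity at melanin-concentrating hormone receptor 1 (Homo sapiens), read by GTPgammaS binding, with a stated time of 45 min; a higher number here means a weaker inhibitor, a lower number a stronger inhibitor. Compound 2 `Cc1ccc(CN2CCC(NC(=O)NCc3ccc(-c4ccccc4)cc3)CC2)cc1` gives 1060 nM in this assay. The change between them, (hydrogen in place of cyano on an aromatic carbon), produced a 2.6-fold higher number from compound 1 to compound 2 (0.41 log units; beyond the scatter). Among the measured compounds shown here, compound 3 `Cc1ccc(CN2CCC(CCN(Cc3ccc(-c4cccc(C#N)c4)cc3)C(=O)NC(C)(C)CO)CC2)cc1` gives 84 nM in this assay, the lowest of the three numbers so far; the difference between its core and the core of compound 1 is not broken down here. Compound 4 `Cc1ccc(CN2CCC(CCN(Cc3ccc(-c4ccccc4)cc3)C(=O)NC(C)(C)CO)CC2)cc1` carries the same change made on the core of compound 3, (hydrogen in place of cyano on an aromatic carbon), at a place described in the same words as for compound 1 and compound 2. For the measured compounds named here, compound 4 is expected to show a 2.6-fold higher number from compound 3 to compound 4 (0.42 log units; beyond the scatter) in this assay, resting on the single earlier step of a 2.6-fold higher number from compound 1 to compound 2 (0.41 log units; beyond the scatter). The estimate for compound 4 in this assay is 220 nM, expected to lie between 110 nM and 450 nM.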

Compound 4, antagonist equilibrium constant: 122 nM
Compound 4: the middle estimate sits 1.8-fold (0.26 log units) above what was measured; the range from low to high includes it.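

In this assay hydrogen in place of cyano gives a 1.5-fold higher number from compound 3 to compound 4 (0.16 log units; within the scatter) on the second core, so here the change stays inside the usual spread of repeat measurements. Set beside the earlier step, the two cores cannot be told apart in their response to this change: the same change on two cores in this assay, a 2.6-fold higher number (0.41 log units; beyond the scatter) from compound 1 to compound 2 and a 1.5-fold higher number (0.16 log units; within the scatter) from compound 3 to compound 4, 1.8-fold (0.25 log units) apart, within the scatter of two such steps

This supports carrying the step between these two cores, but it rests on a single pair per core and does not show that the size of the step is the same on both, or that it would hold on a further core.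

The compounds shown leave open whether a fluorine or a methoxy group at this place would behave as the cyano group does. Also open, as far as these compounds go, is whether an amine or a carboxylic acid there would follow the same course on both cores.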